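Trimming the ethyl branch from compound 2's acid side chain

The compounds below may be only part of what the source reports. "The series", "measured", "known", "first", "only" and "open" are said of these compounds alone.

Of the compounds shown here, three have been measured in a functional assay on CHO cells for antagonist activity at sphingosine 1-phosphate receptor 2 (Homo sapiens), read by GTPgammaS binding; a higher number here means a weaker inhibitor, a lower number a stronger inhibitor. Compound 1 `O=C(O)Cn1nc(Cc2nc3cc(Cl)c(OCC(F)F)cc3[nH]2)c2ccccc2c1=O` gives 15 nM, compound 2 `CCC(C(=O)O)c1nn(Cc2cn3cc(OCC4CC4)c(Cl)cc3n2)c2ccccc2c1=O` gives 43 nM, and compound 3 `COc1cc(OC)c(NC(=O)Cc2nn(CC(=O)O)c(=O)c3ccccc23)cc1Cl` gives 464 nM. Compound 2 therefore stands second highest of the three numbers: compound 1 lies below it by a gap beyond the usual scatter, and compound 3 lies above it by a larger gap, also beyond the scatter. No pair of these compounds differs in only one place, so no single measured step can be read from them.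

Compound 4 `O=C(O)Cc1nn(Cc2cn3cc(OCC4CC4)c(Cl)cc3n2)c2ccccc2c1=O` is not yet measured. It differs from compound 2 in one place: hydrogen in place of ethyl on a saturated chain carbon bound to an aromatic carbon and a carbonyl carbon. Within the data shown here, nothing among the measured compounds isolates the effect of an ethyl branch on this chain carbon, so the direction of the step is open. Compound 1, which carries a carboxymethyl group on a different position of the shared core, gives the lowest number at 15 nM, which speaks against a large loss. Compound 4 is expected to land near compound 2, with an estimated step of a 1.4-fold higher number from compound 2 to compound 4 (0.14 log units; within the scatter) in this assay. Compound 4 is estimated at 60 nM, within a range of 20 nM to 200 nM.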

Compound 4, half-maximal inhibitory concentration: 30 nM
Compound 4: the middle estimate sits 2.0-fold (0.30 log units) above what was measured; low and high end bracket the measured number.
By their numbers in this assay, from the lowest: compounds 1, 4 and 2 (each within the scatter of the next, the first and the last beyond it); then compound 3.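

In this assay, among these compounds, the change from 1-carboxypropyl to carboxymethyl gives the first step that can be read at this position, a 1.4-fold lower number from compound 2 to compound 4 (0.16 log units; within the scatter) for this single exchange of ethyl for hydrogen. The earlier compounds shown here left even the direction of this step open, whereas this pair shows that, on a saturated chain carbon bound to an aromatic carbon and a carbonyl carbon, removing the ethyl group and its 2 heavy atoms leaves no difference that can be separated from the usual scatter, at least with the rest of compound 4 held as it is. No measurement of any property of these compounds bears on the step, so the data offer no explanation for it.

From the compounds shown here alone, what stays open is whether a methyl group, a longer chain such as propyl, or a cyclopropyl ring on this same chain carbon would also stay within the scatter, since one ethyl-to-hydrogen pair cannot show how far the position tolerates change. Whether the carboxymethyl group would behave in the same way on other cores also remains unanswered, as would the effect of replacing its carboxylic acid with an amide or a tetrazole.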